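This account rests on a few compounds, and the source may have more. Where it says the series, first, only, none or still open, it means among the compounds named here.

Measured in a functional assay on K562 cells (Homo sapiens), read by MTT assay, with a stated time of 72 h; a higher number here means a weaker inhibitor, a lower number a stronger inhibitor:
Compound 1 `CNc1ncnc2c1c(-c1ccsc1)cn2[C@@H]1O[C@H](CO)[C@@H](O)[C@H]1O`: > 20000 nM
Compound 2 `Nc1nc(N)c2c(-c3ccco3)cn([C@@H]3O[C@H](CO)[C@@H](O)[C@H]3O)c2n1`: > 20000 nM
Compound 3 `COc1nc(N)nc2c1c(-c1ccco1)cn2[C@@H]1O[C@H](CO)[C@@H](O)[C@H]1O`: > 20000 nM

Each of these entries is a limit of the assay and not a number.

Compound 3 stands at > 20000 nM, which is a limit, and the other two compounds offer no number to set it against.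

The next compound is compound 4 `COc1nc(N)nc2c1c(-c1ccoc1)cn2[C@@H]1O[C@H](CO)[C@@H](O)[C@H]1O`, which has furan-3-yl in place of furan-2-yl on an aromatic carbon of a five-membered aromatic ring with 1 nitrogen, part of a fused or bridged system of two rings: furan-3-yl in place of furan-2-yl on an aromatic carbon. The two compounds have the same atoms, joined differently.

Among the measured compounds shown here, the only measured step is a step that the two limits leave unreadable from compound 2 to compound 3. It concerns methoxy in place of amino, not the furan, and its size cannot be read. For the measured compounds named here, no measured pair shows the furan exchange itself. Going by the values given here, the only guide is therefore (the limit of > 20000 nM in this assay, at which 3 of the 3 values shown sit).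

Among the compounds with values here, with no step of readable size to draw on, a change beyond the scatter is not expected in this assay, and no direction can be given. The expected step is a number no higher from compound 3 to compound 4 (the limit leaves the size open), and most likely it too will remain unreadable behind a limit. Compound 4 is estimated at 20000 nM, with an expected range from 5000 nM to 40000 nM.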

Compound 4, half-maximal inhibitory concentration: > 20000 nM
Compound 4 ended at the assay's limit; the forecaster's own chance of this, stated with the estimate: 85%; the middle value lies on the limit itself.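

In this assay compound 4 gives > 20000 nM, which is a limit of the assay and not a number. Compound 3 also stands at a limit, and the step to compound 4, furan-3-yl in place of furan-2-yl, cannot be read. The compounds shown leave open whether any change on the shared core would give a readable value: the limit of > 20000 nM in this assay, at which 4 of the 4 values shown sit.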